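Methyl for fluorine on the cyclopropyl amide series

This account rests on a few compounds, and the source may have more. Where it says the series, first, only, none or still open, it means among the compounds named here.

Three compounds of the shared core have been run in an assay on SH-EP1 cells for displacement of a labelled ligand from Neuronal acetylcholine receptor; alpha4/beta2 (Homo sapiens), read by scintillation counting; on this read-out lower numbers stand for stronger inhibition and higher numbers for weaker inhibition. Compound 1 `CCC(=O)N1CC2CC(C1)N2` gives 6 nM. Compound 2 `O=C([C@@H]1C[C@@H]1F)N1CC2CC(C1)N2` gives 1.7 nM; compound 3 `O=C([C@@H]1C[C@H]1F)N1CC2CC(C1)N2` gives 1 nM. Compound 3 sits at the favourable end of the set: the step of a 6.0-fold lower number from compound 1 to compound 3 (0.78 log units; beyond the scatter) lies beyond the scatter, while compound 2 lies within the scatter of it, a 1.7-fold lower number from compound 2 to compound 3 (0.23 log units; within the scatter), a pair that differs only as stated in the fact that one of compounds 2 and 3 is drawn with a defined configuration and the other without, at the place where they differ. The parallel step a 3.5-fold lower number from compound 1 to compound 2 (0.55 log units; beyond the scatter) points the same way.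

The next change, (2-methylcyclopropyl in place of 2-fluorocyclopropyl on a carbonyl carbon), gives compound 4 `C[C@H]1C[C@H]1C(=O)N1CC2CC(C1)N2`. For the measured compounds named here, no measured step swaps methyl for fluorine on the cyclopropyl, so the only bearing evidence is the ethyl-to-2-fluorocyclopropyl step from compound 1 to compound 3, which is modest. Part of that gain may belong to the ring and part to the fluorine; with the fluorine removed, a small loss against compound 3 is expected, a 2.0-fold higher number from compound 3 to compound 4 (0.30 log units; within the scatter), not clearly beyond the scatter. Compound 4 is expected at 2 nM, within 0.7 nM to 6 nM.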

Compound 4, inhibition constant: 7 nM
Beside the measured number, compound 4's estimate is 3.5-fold (0.54 log units) below it; measured number outside the range, above it.
By their numbers in this assay, from the lowest: compounds 3 and 2 (each within the scatter of the next); then compounds 1 and 4 (each within the scatter of the next).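

In this assay, the fluoro substituent on the cyclopropyl cannot be exchanged for methyl without loss, whichever fluorinated compound is the reference (a 7.0-fold higher number from compound 3 to compound 4 (0.85 log units; beyond the scatter); a 4.1-fold higher number from compound 2 to compound 4 (0.61 log units; beyond the scatter)). The 2-methylcyclopropyl group also gives no measurable advantage over ethyl (a 1.2-fold higher number from compound 1 to compound 4 (0.07 log units; within the scatter)), so among these compounds the gain over compound 1 appears only with the 2-fluorocyclopropyl group of compounds 2 and 3, and compound 4 does not share it. Nothing measured here explains why methyl and fluoro differ at this position.

Still open, going by these compounds, is whether the unsubstituted cyclopropyl amide sits with compound 1 or with compounds 2 and 3. It is also unknown whether chloro or hydroxyl on the same ring carbon would behave like fluoro or like methyl.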